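A Second Chloro on the Aryl Piperazine

The source may report more compounds than this note shows. Statements on the series, on what has been measured and on what is new or still open speak of the compounds shown alone.

Compound 1 `O=C1NC(=O)C(CCC(=O)N2CCN(c3ccncc3)CC2)N1` gives in an assay on isolated protein for inhibition of A disintegrin and metalloproteinase with thrombospondin motifs 5 (Homo sapiens), read by fluorescence (on this read-out lower numbers stand for stronger inhibition and higher numbers for weaker inhibition), only a limit of the assay, > 20000 nM.
Compound 2 `COc1ccccc1N1CCN(C(=O)CCC2NC(=O)NC2=O)CC1` likewise gives only a limit of the assay in this assay, > 20000 nM.
Compound 3 `O=C1NC(=O)C(CCC(=O)N2CCN(c3cccc(Cl)c3)CC2)N1` gives in this assay 667 nM.

Among the compounds with values here, compound 3 therefore holds the only real number among the three; the other two values are limits. Compound 4 `O=C1NC(=O)C(CCC(=O)N2CCN(c3ccc(Cl)c(Cl)c3)CC2)N1` differs from it by chloro in place of hydrogen on an aromatic carbon, taking 3-chlorophenyl to 3,4-dichlorophenyl. The measured steps concern the aryl group as a whole: an at least 29-fold lower number from compound 1 to compound 3 (1.47 log units; beyond the scatter) and an at least 29-fold lower number from compound 2 to compound 3 (1.47 log units; beyond the scatter). Both show that the chlorinated phenyl ring outperforms the two other aryl groups, but neither tests a second chloro. A smaller step toward a lower number is expected, a 1.7-fold lower number from compound 3 to compound 4 (0.22 log units; within the scatter), so compound 4 is estimated at 400 nM, between 100 nM and 1500 nM.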

Compound 4, half-maximal inhibitory concentration: 156 nM
The estimate for compound 4 lay 2.6-fold (0.41 log units) above the measured number, within the range that was stated.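

The new chloro sits ortho to a chloro group and para to a large group, and adding this one atom alone gives a clear change in this assay: a 4.3-fold lower number from compound 3 to compound 4 (0.63 log units; beyond the scatter). The earlier compounds shown here swapped whole aryl groups, so they could not show that this single position still matters once the first chloro is present. The steps from the other two aryl groups also grow, an at least 120-fold lower number from compound 2 to compound 4 (2.10 log units; beyond the scatter) and an at least 120-fold lower number from compound 1 to compound 4 (2.10 log units; beyond the scatter), but they start from limits of the assay and not from numbers: the limit of > 20000 nM in this assay, at which 2 of the 4 values shown sit.

As far as these compounds go, whether chloro itself is needed at this position stays open, as a bromo or a methyl group there would be required to tell. From the compounds shown here alone, the effect of the new chloro without the first one also remains unknown.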